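Swapping the Side-Chain Ring of Compound 2

The source may hold more compounds than are shown below. What is called first, only, known or untested is meant among the compounds shown, and "the series" means these compounds.

Measured so far in an ADME assay on microsomes from liver (Mus musculus) for metabolic stability; a higher number here means that the compound lasts longer, a lower number that the compound disappears faster:
compound 1, `CCn1ncc2c(F)cc(-c3ccc(C(CC)(CC)c4nnc[nH]4)c(=O)[nH]3)cc21`, gives > 3 h, a limit of the assay rather than a number.
compound 2, `CC(C)C(c1ccc(-c2ccc3cccc(F)c3c2)[nH]c1=O)N1CCCCC1=O`, gives 0.0967 h.

For the measured compounds named here, compound 2 is the only compound with a true number in this assay, and that number is short. Going by the values given here, the other measured compound cannot be ranked against it in the usual way, since (the limit of > 3 h in this assay, at which 1 of the 2 values shown sits), so no step between measured compounds is known here.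

Compound 3, `CC(C)C(c1ccc(-c2ccc3cccc(F)c3c2)[nH]c1=O)N1CCNC1=O`, is built from compound 2 by a single change: 2-oxoimidazolidin-1-yl in place of 2-oxopiperidin-1-yl on a saturated chain carbon bound to an aromatic carbon and a saturated chain carbon. Among the compounds with values here, nothing measured tells how such a change moves the half-life, so the expectation for the step from compound 2 to compound 3 rests on no measured precedent. The step of a 2.1-fold higher number from compound 2 to compound 3 (0.32 log units; beyond the scatter) in this assay is expected to be small and upward, at most a little beyond the usual scatter of repeated measurements, with a downward result also possible. Compound 3 is therefore estimated at 0.2 h, with a range from 0.07 h to 0.6 h.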

Compound 3, half-life: 0.682 h
Compound 3: middle estimate off by 3.4-fold (0.53 log units), on the low side; measured number above the stated range.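

For the compounds shown here, until now, no step at this position was known. In this assay, placing 2-oxoimidazolidin-1-yl where 2-oxopiperidin-1-yl stood gives a 7.1-fold higher number from compound 2 to compound 3 (0.85 log units; beyond the scatter) and shows that the half-life responds to the ring on this saturated chain carbon, by more than the usual scatter. The change replaces a six-membered non-aromatic ring with 1 hetero atom and no hydrogen-bond donor by a five-membered one with 2 hetero atoms and a hydrogen-bond donor, but this single pair cannot show which of these differences matters, and nothing measured here explains the step.

The compounds shown leave open whether ring size or the additional ring nitrogen with its hydrogen goes with the longer half-life, a question that 2-oxopyrrolidin-1-yl, a five-membered ring with only one nitrogen, could help to separate. Also open, going by these compounds, is how other groups at this place, such as an open-chain amide or an amine, would behave, and whether the same ring change would move the half-life in the same direction on a different core.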